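From a piperidinyl amine to a cyclobutylpiperazine

The compounds below may be only part of what the source reports. "The series", "measured", "known", "first", "only" and "open" are said of these compounds alone.

Compound 1 `NC1CCN(c2nc3c(c(Nc4ccc(C(F)(F)F)cc4)n2)CCN(c2ncccc2C(F)(F)F)CC3)C1`: > 215 ug/mL
Compound 2 `CN(c1nc2c(c(Nc3ccc(C(F)(F)F)cc3)n1)CCN(c1ncccc1C(F)(F)F)CC2)C1CCCNC1`: 211 ug/mL

Compound 1 stands at > 215 ug/mL in a physicochemical assay for solubility, in simulated intestinal fluid, measured as thermodynamic solubility, at pH 6.8 (a higher number here means a more soluble compound, a lower number a less soluble compound), and that reading is a limit, not a number. Among the compounds with values here, compound 2 gives 211 ug/mL in this assay as the only true number so far. Within the data shown here, the one measured step is an at least 1.0-fold lower number from compound 1 to compound 2 (0.00 log units; that floor lies within the scatter) and it lies at the same aromatic carbon as the change now in question, so it bears directly, yet it offers a floor and no real size.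

Compound 3 `FC(F)(F)c1ccc(Nc2nc(N3CCN(C4CCC4)CC3)nc3c2CCN(c2ncccc2C(F)(F)F)CC3)cc1` carries 4-cyclobutylpiperazin-1-yl in place of methyl(piperidin-3-yl)amino on that carbon, and the rest of the molecule stays the same. The counted change is this: 4-cyclobutylpiperazin-1-yl in place of methyl(piperidin-3-yl)amino on an aromatic carbon and the entering group brings a four-membered non-aromatic ring of carbon only.

With compound 2 at 211 ug/mL as the anchor and no measured swap at this place moving beyond the scatter, a modest fall is expected, though no change at all remains possible. The expected step is a 1.6-fold lower number from compound 2 to compound 3 (0.21 log units; within the scatter) and it carries wide uncertainty. Compound 3 is estimated at 130 ug/mL with an expected range of 40 ug/mL to 240 ug/mL in this assay for now.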

Compound 3, solubility: 2 ug/mL
Beside the measured number, compound 3's estimate is 65-fold (1.81 log units) above it; the measured number lies below the stated range.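

The swap at this aromatic carbon gives a 110-fold lower number from compound 2 to compound 3 (2.02 log units; beyond the scatter), so unlike the earlier step, which offered only a floor within the scatter, this one shows that the group at this position can move the reading strongly in this assay. Compound 1 reads > 215 ug/mL, which is a limit and not a number. Measured against that limit, the change is an at least 100-fold lower number from compound 1 to compound 3 (2.03 log units; beyond the scatter), a large step that stands only as a floor because it starts from a limit: the limit of > 215 ug/mL in this assay, at which 1 of the 3 values shown sits.

The change from compound 2 to compound 3 replaces one six-membered non-aromatic ring with another, adds a four-membered non-aromatic ring of carbon only and leaves 0 hydrogen-bond donors in the entering group, and the compounds shown do not separate these parts. A piperazin-1-yl group with a free ring nitrogen, or a 4-methylpiperazin-1-yl group, on the same carbon would show whether the fall follows the piperazine ring itself or the cyclobutyl ring on it.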